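A Nitrophenyl Swap on a Series at Its Limit

A few compounds are considered here, and "the series" means these few. Any claim that something is new, unique, unknown or untested is made for them only; others in the source may bear on it.

Compound 1 (`COc1ccccc1-n1cc(COC(=O)/C(C)=C/CC/C(C)=C/CC/C(C)=C/CC[C@@H]2[C@@]3(C)CCC(=O)C(C)(C)[C@H]3CC[C@@]2(C)O)nn1`) and compound 2 (`C/C(=C\CC/C(C)=C/CC[C@@H]1[C@@]2(C)CCC(=O)C(C)(C)[C@H]2CC[C@@]1(C)O)CC/C=C(\C)C(=O)OCc1cn(-c2ccc(F)c(Cl)c2)nn1`) have the shared core in common and differ in the aryl group on the triazole-type ring, a five-membered aromatic ring with 3 nitrogen. In a functional assay on A549 cells (Homo sapiens) for antiproliferative activity, read by MTT assay, with a stated time of 48 h (on this read-out higher numbers stand for weaker inhibition and lower numbers for stronger inhibition), compound 1 gives > 150000 nM, which is a limit and not a number. Compound 2 gives > 150000 nM, again only a limit. Within the data shown here, compound 2 therefore has no number of its own, and the one other value beside it is also a limit: the limit of > 150000 nM in this assay, at which 2 of the 2 values shown sit.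

Compound 3 (`C/C(=C\CC/C(C)=C/CC[C@@H]1[C@@]2(C)CCC(=O)C(C)(C)[C@H]2CC[C@@]1(C)O)CC/C=C(\C)C(=O)OCc1cn(-c2cccc([N+](=O)[O-])c2)nn1`) carries 3-nitrophenyl in place of 3-chloro-4-fluorophenyl on an aromatic nitrogen.

Among the measured compounds shown here, the only measured step bearing on this change is a step that the two limits leave unreadable from compound 1 to compound 2, where 3-chloro-4-fluorophenyl replaced 2-methoxyphenyl at the same place. For the measured compounds named here, it offers no size to carry over, so with the limit of > 150000 nM in this assay, at which 2 of the 2 values shown sit, as the sole guide, no step beyond the scatter is expected in this assay, and no direction can be expected either. The estimated step is a number no higher from compound 2 to compound 3 (the limit leaves the size open). For compound 3 the expected value is about 150000 nM, with an estimated range from 70000 nM to 300000 nM.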

Compound 3, half-maximal inhibitory concentration: > 150000 nM
Compound 3 ended at the assay's limit; the forecaster's own chance of this, stated with the estimate: 80%; the middle value lies on the limit itself.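

In this assay compound 3 gives > 150000 nM, a limit and not a number. The steps among compound 1, compound 2 and compound 3 therefore cannot be read. The compounds shown leave open whether the aryl group on the triazole-type ring changes the activity at all, because none of them has a number of its own: the limit of > 150000 nM in this assay, at which 3 of the 3 values shown sit.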